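The compounds below may be only part of what the source reports. "The series", "measured", "known", "first", "only" and "open" are said of these compounds alone.

Series notes. Within the data shown here, compound 3 `Cc1[nH]c2ccccc2c1-c1ccnc(Nc2cccnc2)n1` gives 100 nM in an assay on isolated protein for inhibition of interferon-induced, double-stranded RNA-activated protein kinase (Homo sapiens), read by luminescence, with a stated time of 10 min (a higher number here means a weaker inhibitor, a lower number a stronger inhibitor), the lowest of the three numbers so far; compound 1 `Cc1[nH]c2ccccc2c1-c1ccnc(NCCO)n1` gives 11000 nM and compound 2 `Cc1[nH]c2ccccc2c1-c1ccnc(NC(CO)C(C)C)n1` gives 50000 nM. The steps of a 110-fold lower number from compound 1 to compound 3 (2.04 log units; beyond the scatter) and a 500-fold lower number from compound 2 to compound 3 (2.70 log units; beyond the scatter) are both large, while a 4.5-fold higher number from compound 1 to compound 2 (0.66 log units; beyond the scatter) is modest. Compound 4 `Cc1[nH]c2ccccc2c1-c1ccnc(Nc2ccccc2Cl)n1` differs from compound 3 by 2-chlorophenyl in place of pyridin-3-yl on a nitrogen on an aromatic ring. Among the measured compounds shown here, both large measured steps replace a saturated chain with an aromatic ring; none exchanges one aromatic ring for another, so no measured step bears directly on this change. Since an aromatic ring is kept, the expected step of a 2.0-fold higher number from compound 3 to compound 4 (0.30 log units; within the scatter) is small, with no confident direction beyond the scatter. Compound 4 is therefore estimated at about 200 nM, within 50 nM to 1000 nM.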

Compound 4, half-maximal inhibitory concentration: 19000 nM
For compound 4 the middle estimate is 95-fold (1.98 log units) below the measured one, outside the stated range (above it).
By their numbers in this assay, from the lowest: compound 3; then compounds 1 and 4 (each within the scatter of the next); then compound 2.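

In this assay, keeping an aromatic ring on this nitrogen does not preserve the low number: the exchange of pyridin-3-yl for 2-chlorophenyl is a large step (a 190-fold higher number from compound 3 to compound 4 (2.28 log units; beyond the scatter)). The 2-chlorophenyl group gives no gain over the saturated chains, with a step within the scatter against 2-hydroxyethyl (a 1.7-fold higher number from compound 1 to compound 4 (0.24 log units; within the scatter)) and only a modest one against 1-(hydroxymethyl)-2-methylpropyl (a 2.6-fold lower number from compound 2 to compound 4 (0.42 log units; beyond the scatter)). Nothing available accounts for this loss.

The exchange removes the ring nitrogen and adds chlorine together, and the compounds shown do not separate the two. Plain phenyl and pyridin-4-yl remain open at this position.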